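A few compounds are considered here, and "the series" means these few. Any claim that something is new, unique, unknown or untested is made for them only; others in the source may bear on it.

Measured in a functional assay on C6 cells (Rattus norvegicus) for cytotoxicity, read by MTT assay, with a stated time of 24 h; on this read-out lower numbers stand for stronger inhibition and higher numbers for weaker inhibition:
compound 1 `Cn1nnnc1SCC(=O)N/N=c1/scc(-c2ccccc2)n1-c1ccccc1` gives 67.7 ug/mL;
compound 2 `COc1ccc(-c2cs/c(=N/NC(=O)CSc3nnnn3C)n2-c2ccccc2)cc1` gives "not determined" (no result reported);
compound 3 `Cc1ccc(-c2cs/c(=N/NC(=O)CSc3nnnn3C)n2-c2ccccc2)cc1` gives 36.3 ug/mL.

Compound 1 and compound 3 lie within the scatter of each other, and compound 2 has no result, so compound 1 has no measured neighbour set apart from it. Among the measured compounds shown here, the single measured step, a 1.9-fold lower number from compound 1 to compound 3 (0.27 log units; within the scatter), concerns methyl in place of hydrogen on an aromatic carbon. Compound 4 `Cn1cnnc1SCC(=O)N/N=c1/scc(-c2ccccc2)n1-c1ccccc1` differs from compound 1 at another place: 4-methyl-4H-1,2,4-triazol-3-yl in place of 1-methyl-1H-tetrazol-5-yl on a sulfur. For the measured compounds named here, no measured step touches the group on the sulfur, so the data give no direct guide; they show only that one change elsewhere left the number within the scatter. The expectation is therefore no step beyond the scatter, a 1.0-fold lower number from compound 1 to compound 4 (0.02 log units; within the scatter). Compound 4 is estimated at 65 ug/mL, within 30 ug/mL to 140 ug/mL.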

Compound 4, half-maximal inhibitory concentration: 68.3 ug/mL
Compound 4: middle estimate off by 1.1-fold (0.02 log units), on the low side; low and high end bracket the measured number.
By their numbers in this assay, from the lowest: compounds 3, 1 and 4 (each within the scatter of the next).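

In this assay, the group on the sulfur now has a measured step of its own: a 1.0-fold higher number from compound 1 to compound 4 (0.00 log units; within the scatter) for 4-methyl-4H-1,2,4-triazol-3-yl in place of 1-methyl-1H-tetrazol-5-yl. Here, a five-membered aromatic ring with 3 hetero atoms and one with 4 hetero atoms are not told apart by this read-out. Nothing measured here accounts for this outcome.

From the compounds shown here alone, whether an amine or a carboxylic acid on the sulfur would stay within the scatter remains open. So does whether the same exchange holds on compound 3.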